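The source may report more compounds than this note shows. Statements on the series, on what has been measured and on what is new or still open speak of the compounds shown alone.

Compound 1 `O=C(CCc1cccc2c1B(O)OC2)Nc1cccc(-c2ccc(F)cc2)c1` gives 250 nM
Compound 2 `O=C(CCc1cccc2c1B(O)OC2)Nc1cccc(-c2ccc(C(F)(F)F)cc2)c1` gives 510 nM

In a functional assay on MDA-MB-231 cells (Homo sapiens) for antiproliferative activity, read by MTT assay, with a stated time of 72 h (a higher number here means a weaker inhibitor, a lower number a stronger inhibitor), compound 2 at 510 nM holds the higher of the two numbers, so it is the weaker inhibitor of the pair. Compound 3 `CC(=O)c1cccc(-c2cccc(NC(=O)CCc3cccc4c3B(O)OC4)c2)c1` differs from compound 2 in one place, with 3-acetylphenyl in place of 4-(trifluoromethyl)phenyl on an aromatic carbon and the rest unchanged. Going by the values given here, the one measured step bearing on this is a 2.0-fold higher number from compound 1 to compound 2 (0.31 log units; beyond the scatter) and it was modest, made on that same aromatic ring. A step of similar or smaller size is therefore expected in this assay toward a lower number, possibly none beyond the scatter. The expected move is a 1.3-fold lower number from compound 2 to compound 3 (0.11 log units; within the scatter) in this estimate. Compound 3 is expected at 400 nM within a range of 150 nM to 1000 nM as an estimate.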

Compound 3, half-maximal inhibitory concentration: 52 nM
Compound 3: middle estimate off by 7.7-fold (0.89 log units), on the high side, outside the stated range (below it).
By their numbers in this assay, from the lowest: compound 3; then compound 1; then compound 2.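

In this assay, the 3-acetylphenyl ring gives a 9.8-fold lower number from compound 2 to compound 3 (0.99 log units; beyond the scatter) and a 4.8-fold lower number from compound 1 to compound 3 (0.68 log units; beyond the scatter), so compound 3 is the strongest inhibitor of the three. The swap between the two halogen-bearing rings had moved the number far less, so this position can matter more than that pair suggested. This change alters both the group and its place on the ring, so neither can be credited alone.

From the compounds shown here alone, how 4-acetylphenyl or a ring carrying an amine would compare remains open. Nothing available here explains the gain in activity.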